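Replacing an acetoxy group with a sulfonamide on the cyclohexyl ring

This account rests on a few compounds, and the source may have more. Where it says the series, first, only, none or still open, it means among the compounds named here.

Measured compounds:
compound 1, `O=C(OC1CCC(CN2CCN(c3cc(=O)c4cc(C(F)(F)F)cc([N+](=O)[O-])c4s3)CC2)CC1)c1ccc(F)cc1`, 0.0817 h in an ADME assay on cells (Hepatocyte, Mus musculus) for metabolic stability; on this read-out higher numbers stand for a longer-lived compound and lower numbers for a shorter-lived compound
compound 2, `CC(=O)OC1CCC(CN2CCN(c3cc(=O)c4cc(C(F)(F)F)cc([N+](=O)[O-])c4s3)CC2)CC1`, < 0.15 h in this assay

Of the compounds shown here, two have been measured so far. In this assay compound 1 gives 0.0817 h. For compound 2 only a limit of the assay is known, < 0.15 h, so compound 2 stands at the limit of < 0.15 h in this assay, at which 1 of the 2 values shown sits, rather than on a number. Within the data shown here, the one step between them, a step that the limit leaves unreadable from compound 1 to compound 2, cannot be read for size because one of its two ends is a limit.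

Compound 3, `O=c1cc(N2CCN(CC3CCC(NS(=O)(=O)c4ccccc4)CC3)CC2)sc2c([N+](=O)[O-])cc(C(F)(F)F)cc12`, has not yet been measured. It differs from compound 2 by (phenylsulfonyl)amino in place of acetoxy on a saturated ring carbon. No measured step touches this part of the molecule, and the single step measured so far is itself unreadable, so there is nothing among the shown numbers that points to a direction or a size for the change from compound 2 to compound 3. The estimate for compound 3 therefore rests on where compound 1 and compound 2 stand, both at very short half-lives in this assay.

Compound 3 is expected to give 0.25 h, within 0.08 h to 0.8 h, which would mean an estimated step of an at least 1.6-fold higher number from compound 2 to compound 3 (0.22 log units; that floor lies within the scatter).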

Compound 3, half-life: > 1.55 h
Compound 3 was reported as a limit; the forecaster's own chance of this, stated with the estimate: 35%; middle value at least 6.2-fold (0.79 log units) away from the limit.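

Putting (phenylsulfonyl)amino in place of acetoxy on the saturated ring carbon gives an at least 10-fold higher number from compound 2 to compound 3 (1.01 log units; beyond the scatter) in this assay, and the same group in place of ((4-fluorophenyl)carbonyl)oxy gives an at least 18-fold higher number from compound 1 to compound 3 (1.27 log units; beyond the scatter). Among these compounds, the step between compound 1 and compound 2 cannot be read, so these are the first readable changes at this position, and they show that the read-out of the shared core is not held at very short half-lives whatever this ring carbon carries. Compound 3 is known only as a limit, so its steps give a floor and no final size: the limit of > 1.55 h in this assay, at which 1 of the 3 values shown sits.

The compounds shown do not separate the parts of the entering group, so a methylsulfonylamino group, a benzoylamino group or a plain amine on the same ring carbon would be needed to tell whether the phenyl ring, the sulfonyl or the nitrogen carries the step. They also leave open how far the read-out of compound 3 lies past its limit, and whether the same change would give a step of this size on a core with other substituents.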